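Methyl ester indoline-fused series: halogen exchange on the aromatic ring

This account rests on a few compounds, and the source may have more. Where it says the series, first, only, none or still open, it means among the compounds named here.

The series shares one pentacyclic core carrying a methyl ester, with a single halogen on the aromatic ring. Compound 1 `COC(=O)[C@@]1(C)CC[C@@H]2C3=C1CC[C@@H](C)[C@]3(C)C[C@@H]1c3cc(Br)ccc3N[C@H]21` carries bromo; in a functional assay on HBL-100 cells (Homo sapiens) for inhibition, read by sulforhodamine B assay, with a stated time of 48 h (a higher number here means a weaker inhibitor of growth, a lower number a stronger inhibitor of growth), compound 1 gives 34000 nM. Compound 2 `COC(=O)[C@@]1(C)CC[C@@H]2C3=C1CC[C@@H](C)[C@]3(C)C[C@@H]1c3cc(Cl)ccc3N[C@H]21` carries chloro in place of bromo on an aromatic carbon, and in this assay compound 2 gives 28000 nM; the resulting step is a 1.2-fold lower number from compound 1 to compound 2 (0.08 log units; within the scatter). Compound 3 `COC(=O)[C@@]1(C)CC[C@@H]2C3=C1CC[C@@H](C)[C@]3(C)C[C@@H]1c3cccc(Br)c3N[C@H]21` has the same atoms as compound 1 joined differently; the difference between the two cores is not broken down here. In this assay compound 3 gives 40000 nM. All three values lie within the scatter of one another, so no order among them is read.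

Compound 4 `COC(=O)[C@@]1(C)CC[C@@H]2C3=C1CC[C@@H](C)[C@]3(C)C[C@@H]1c3cccc(Cl)c3N[C@H]21` is not yet measured. It differs from compound 3 by chloro in place of bromo on an aromatic carbon. The surroundings are not the same as in the earlier pair: here the carbon is ortho to a fused ring and meta to a fused ring, whereas in the earlier pair it is meta to a fused ring and para to a fused ring, so this is the same kind of change, not the same change. The expected step is a 1.2-fold lower number from compound 3 to compound 4 (0.07 log units; within the scatter), placed beside a 1.2-fold lower number from compound 1 to compound 2 (0.08 log units; within the scatter), and it rests on that earlier step. Compound 4 is therefore expected to give about 34000 nM, within roughly 20000 nM to 60000 nM.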

Compound 4, concentration for 50% growth inhibition: 52000 nM
For compound 4 the middle estimate is 1.5-fold (0.18 log units) below the measured one; the range from low to high includes it.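

Chloro in place of bromo on an aromatic carbon has now been read on two cores in this assay, and the new step is a 1.3-fold higher number from compound 3 to compound 4 (0.11 log units; within the scatter). Set beside the earlier step, the two cannot be told apart: the same change on two cores in this assay, a 1.2-fold lower number (0.08 log units; within the scatter) from compound 1 to compound 2 and a 1.3-fold higher number (0.11 log units; within the scatter) from compound 3 to compound 4, 1.6-fold (0.20 log units) apart, within the scatter of two such steps. The exchange therefore stays within the scatter on both cores in this assay, but no direction can be assigned to it, and these two pairs do not show that it would stay this small on any other core or in any other assay.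

The compounds shown leave open whether an amine or a methoxy group on this aromatic carbon would give a step beyond the scatter, since only bromo and chloro are covered here. They also leave open what a carboxylic acid or an amide in place of the methyl ester would do to growth inhibition in this assay.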